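The source may hold more compounds than are shown below. What is called first, only, known or untested is meant among the compounds shown, and "the series" means these compounds.

Compound 1, `C[C@@H](NC(=O)c1ccc(C#Cc2cccc(F)c2)nc1)C(C)(C)O`, gives 64.9%.
Compound 2, `Cc1cc(C(=O)N[C@H](C)C(C)(C)O)ncc1C#Cc1cccc(F)c1`, gives 66.6%.
Compound 3, `CCCNC(=O)c1ccc(C#Cc2cccc(F)c2)cn1`, gives 65.9%.

The three measured compounds were tested in a functional assay on HEK293 cells for positive allosteric modulation of metabotropic glutamate receptor 5 (Rattus norvegicus), read by fluorescence and calcium flux; a lower number here means a smaller maximal response, a higher number a larger maximal response. Compound 3 stands second highest of the three numbers, yet its value lies within the usual scatter of both neighbours: compound 2 sits a little higher and compound 1 a little lower, and neither gap is large enough to call a difference. Across these three, the maximal response has therefore stayed essentially flat despite the changes in the amide substituent and the shared core.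

Compound 4, `CC1(CNC(=O)c2ccc(C#Cc3cccc(F)c3)cn2)COC1`, has not yet been measured in this assay. It follows from compound 3 by one change: 3-methyloxetan-3-yl in place of ethyl on a saturated chain carbon bound to an amide-type nitrogen. For the measured compounds named here, no measured pair shows this particular replacement, so its effect on the maximal response is unknown from the data at hand. Given how flat the maximal response has been across compounds 1, 2 and 3, the step is expected to be small, most likely within the scatter, with no clear direction; the step from compound 3 to compound 4 is estimated at a number 2.9 percentage points lower from compound 3 to compound 4 (within the scatter). Compound 4 is expected to give about 63%, in a range from 48% to 78%.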

Compound 4, largest response reached (reported as efficacy), in percent of the reference or control that the assay uses: 60.4%
Beside the measured number, compound 4's estimate is 2.6 percentage points above it; measured number inside the range.
By their numbers in this assay, from the lowest: compounds 4, 1, 3 and 2 (each within the scatter of the next).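

Swapping ethyl for 3-methyloxetan-3-yl on a saturated chain carbon bound to an amide-type nitrogen gives, in this assay, a number 5.5 percentage points lower from compound 3 to compound 4 (within the scatter) for the maximal response. For the compounds shown here, this is the first reading at this position, and it shows that a group with more heavy atoms, a four-membered non-aromatic ring and a hydrogen-bond acceptor can enter there without a step beyond the scatter. Nothing in the data at hand bears on why the response holds at this place.

The compounds shown leave open how a longer chain, an amine or a carboxylic acid on the same chain carbon would read in this measurement. They also leave open whether 3-methyloxetan-3-yl would give a similar step on the amide substituents of compound 1 and compound 2.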